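This account rests on a few compounds, and the source may have more. Where it says the series, first, only, none or still open, it means among the compounds named here.

In a functional assay on A549 cells (Homo sapiens) for inhibition, read by sulforhodamine B assay, with a stated time of 72 h (a higher number here means a weaker inhibitor of growth, a lower number a stronger inhibitor of growth), three compounds have been measured so far. Compound 1 `O=C(/C=C/c1ccncc1-c1ccc2cc[nH]c2c1)N1CCOCC1` gives > 10000 nM, which is a limit of the assay and not a number. Compound 2 `Cn1ncc2cc(-c3cnccc3/C=C/C(=O)O)ccc21` gives > 10000 nM, again a limit. Compound 3 `COC1CN(C(=O)/C=C/c2ccncc2-c2ccc3ccccc3c2)C1` gives > 10000 nM, also a limit, and so it stands level with the other two as far as can be told. Compound 4 `O=C(/C=C/c1ccncc1-c1ccc2ccccc2c1)NC1CC1` carries cyclopropylamino in place of the 3-methoxyazetidin-1-yl of compound 3 on a carbonyl carbon, (cyclopropylamino in place of 3-methoxyazetidin-1-yl on a carbonyl carbon). No step beyond the scatter is expected in this assay because the limit of > 10000 nM in this assay, at which 3 of the 3 values shown sit, is all the measurements show. The expected change is a number no higher from compound 3 to compound 4 (the limit leaves the size open). Compound 4 is estimated at about 10000 nM, with an expected range of 4000 nM to 30000 nM.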

Compound 4, concentration for 50% growth inhibition: 5840 nM
Beside the measured number, compound 4's estimate is 1.7-fold (0.23 log units) above it; the range from low to high includes it.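

For the compounds shown here, compound 4 is the only compound here that gives a number rather than a limit in this assay, so this carbonyl position can carry a readable result. Cyclopropylamino in place of 3-methoxyazetidin-1-yl gives an at least 1.7-fold lower number from compound 3 to compound 4 (0.23 log units; that floor lies within the scatter). Only a floor can be stated for this step, and its true size stays unknown: the limit of > 10000 nM in this assay, at which 3 of the 4 values shown sit.

Going by these compounds, whether the result goes with the amide hydrogen or with the three-membered ring remains open. An open-chain group such as ethylamino or dimethylamino on the same carbonyl carbon would help separate the two.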